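A few compounds are considered here, and "the series" means these few. Any claim that something is new, unique, unknown or untested is made for them only; others in the source may bear on it.

Measured so far in a functional assay on SK-MEL-5 cells (Homo sapiens) for cytotoxicity; on this read-out higher numbers stand for an effect only at larger amounts of compound and lower numbers for an effect already at smaller amounts
- compound 1 `CCOc1ccc(/C=C/c2cc(OC)c(OC)c(OC)c2)cc1` gives 1.17 uM
- compound 2 `COc1cc(/C=C/c2ccc(SC)cc2)cc(OC)c1OC` gives 2.8 uM

Of these two, compound 1 holds the lower number, and compound 2 is its nearest neighbour. Compound 3 `CCOc1ccc(/C=C\c2cc(OC)c(OC)c(OC)c2)cc1` has not yet been measured. The change from compound 1 to compound 3 is purely one of configuration (the two compounds have the same atoms and bonds and differ only in configuration as drawn: 1 of 1 stereo elements differ; a double bond is drawn E in compound 1 and Z in compound 3), so no group leaves or enters.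

Among the measured compounds shown here, the only measured step is a 2.4-fold higher number from compound 1 to compound 2 (0.38 log units; beyond the scatter) and its change is methylsulfanyl in place of ethoxy on an aromatic carbon. That step leaves the double bond untouched, so it bears on the present change only weakly. For the measured compounds named here, no measured pair here compares a double bond drawn E with one drawn Z, and the size of the step stays uncertain. Even so, a move to a lower number in this assay is expected, larger than that modest measured step. The estimate is a 12-fold lower number from compound 1 to compound 3 (1.07 log units; beyond the scatter) with wide margins. Compound 3 is thus expected at 0.1 uM with 0.015 uM to 1 uM as the estimated range.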

Compound 3, concentration for half-maximal effect: 2.5 uM
Estimate against measurement, compound 3: 25-fold (1.40 log units) below; the measured number lies above the stated range.
By their numbers in this assay, from the lowest: compound 1; then compounds 3 and 2 (each within the scatter of the next).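

Among the compounds shown here, with a 2.1-fold higher number from compound 1 to compound 3 (0.33 log units; beyond the scatter) in this assay, the picture gains a second kind of change: until now the only measured step had swapped a group on an aromatic carbon, whereas this one leaves every group in place and turns the double bond alone. The result shows that the drawn configuration of this double bond counts on its own account, and that for the ethoxy compounds the E form, compound 1, holds the lower number and the Z form, compound 3, does not improve on it. The step can be put down to the double bond and nothing else, because no other feature separates the pair: the fact that compounds 1 and 3 differ only in the configuration as drawn

Going by these compounds, whether the double bond counts for as much once the ethoxy gives way to methylsulfanyl, to an amine or to a longer chain such as butoxy remains open, as the configuration has been compared with the ethoxy group alone. Also open, on these data alone, is whether the same order of the E and Z forms would hold on cells other than this one melanoma line.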